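A few compounds are considered here, and "the series" means these few. Any claim that something is new, unique, unknown or untested is made for them only; others in the source may bear on it.

Among the measured compounds shown here, in a functional assay on HepG2 cells (Homo sapiens) for cytotoxicity, read by sulforhodamine B assay, with a stated time of 48 h (on this read-out lower numbers stand for stronger inhibition of growth and higher numbers for weaker inhibition of growth), the compounds measured so far read as follows.

Compound 1 `Cc1nn(-c2ccccc2)c(Oc2ccc(-c3nc4cc([N+](=O)[O-])ccc4[nH]3)cc2)c1/C=N/NC(N)=O` gives 47700 nM
Compound 2 `Cc1nn(-c2ccccc2)c(Sc2ccc(-c3nc4cc(C(=O)O)ccc4[nH]3)cc2)c1/C=N/NC(N)=O` gives "not determined" (no result reported)
Compound 3 `COc1ccc(N/N=C/c2c(C)nn(-c3ccccc3)c2Oc2ccc(-c3nc4cc(C(N)=O)ccc4[nH]3)cc2)cc1` gives "not determined" (no result reported)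

Compound 3 has no place on the scale of this assay, since its entry holds no single number. For the measured compounds named here, compound 2 is the one further entry without a number, which leaves compound 1 as the only compound with a measured value. Compound 4 `Cc1nn(-c2ccccc2)c(Oc2ccc(-c3nc4cc(C(N)=O)ccc4[nH]3)cc2)c1/C=N/Nc1ccc([N+](=O)[O-])cc1` has not yet been measured. Its structure departs from that of compound 3 in a single place, (nitro in place of methoxy on an aromatic carbon). The change lies para to a large group and turns 4-methoxyphenyl into 4-nitrophenyl.

No measured step between any of these compounds is available as a guide, and compound 3 offers no number from which to start. A step beyond the usual scatter in this assay is therefore not expected, and no direction is assumed, although the data cannot test this. Going by the values given here, the only anchor is compound 1 at 47700 nM, and the expectation is set near that level with a wide margin. For compound 4 the estimated value is 30000 nM, with an expected range from 8000 nM to 100000 nM.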

Compound 4, concentration for 50% growth inhibition: 45500 nM
The estimate for compound 4 lay 1.5-fold (0.18 log units) below the measured number; the measured number falls inside the stated range.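

In this assay compound 4 gives 45500 nM while compound 3 holds no single number, so no step can be read for the change from 4-methoxyphenyl to 4-nitrophenyl. The compounds shown leave open what that change does to growth inhibition on the shared core. No evidence at hand bears on this result.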